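Removing the methoxy group from a pyrazoline growth inhibitor

A few compounds are considered here, and "the series" means these few. Any claim that something is new, unique, unknown or untested is made for them only; others in the source may bear on it.

Measured compounds:
compound 1 `O=C(C1COc2ccccc2O1)N1N=C(c2ccccc2)CC1c1ccc(F)cc1` — 3270 nM
compound 2 `COc1ccc(C2=NN(C(=O)C3COc4ccccc4O3)C(c3ccccc3F)C2)cc1` — 5720 nM

In a functional assay on WM 266-4 cells (Homo sapiens) for inhibition, read by MTT assay, with a stated time of 24 h (a lower number here means a stronger inhibitor of growth, a higher number a weaker inhibitor of growth), compound 2 gives 5720 nM and compound 1 gives 3270 nM; the two values lie within the usual scatter of each other, so neither stands apart. Compound 3 `O=C(C1COc2ccccc2O1)N1N=C(c2ccccc2)CC1c1ccccc1F` differs from compound 2 by hydrogen in place of methoxy on an aromatic carbon. Among the measured compounds shown here, no step between measured compounds isolates this change, so the account rests on these two values alone. Compound 3 is expected to show a step of about a 1.1-fold lower number from compound 2 to compound 3 (0.06 log units; within the scatter), which is no change beyond the scatter, and its value in this assay is estimated at 5000 nM, between 2000 nM and 12000 nM.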

Compound 3, concentration for 50% growth inhibition: 1490 nM
The estimate for compound 3 lay 3.4-fold (0.53 log units) above the measured number, outside the stated range (below it).
By their numbers in this assay, from the lowest: compound 3; then compounds 1 and 2 (each within the scatter of the next).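

Replacing the methoxy group with hydrogen gives a 3.8-fold lower number from compound 2 to compound 3 (0.58 log units; beyond the scatter) and so shows that the group on this aromatic carbon, para to a large group, matters for growth inhibition in this series. Compound 3 also stands apart from compound 1 through a 2.2-fold lower number from compound 1 to compound 3 (0.34 log units; beyond the scatter) with 2-fluorophenyl in place of 4-fluorophenyl, so the place of the fluorine matters too. Nothing given here bears on why either step arises. From the compounds shown here alone, how an amine or a hydroxyl group would fare on that carbon stays open, as does whether the methoxy step holds when 4-fluorophenyl is present.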